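The compounds below may be only part of what the source reports. "The series", "measured", "known", "first", "only" and "open" are said of these compounds alone.

The measured compounds:
compound 1, `O=C(Nc1ccc(OC(=O)c2cc3cc([N+](=O)[O-])ccc3s2)cc1)Nc1ccc(Oc2ccccc2)cc1`, with 13300 nM in a functional assay on HT-29 cells (Homo sapiens) for antiproliferative activity, read by MTT assay, with a stated time of 48 h; on this read-out lower numbers stand for stronger inhibition and higher numbers for weaker inhibition;
compound 2, `COc1ccc(C(=O)Oc2ccc(NC(=O)Nc3ccc(Cl)c(C(F)(F)F)c3)cc2)cc1`, with 33800 nM in this assay;
compound 3, `O=C(Nc1ccccc1)Nc1ccc(OC(=O)c2ccccc2)cc1`, with 123000 nM in this assay.

Compound 3 stands highest of the three numbers. Its nearest neighbour is compound 2, whose number is lower by a margin beyond the scatter, and compound 1 lies further off still, also beyond the scatter.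

Compound 4, `O=C(Nc1ccccc1)Nc1ccc(OC(=O)c2ccc([N+](=O)[O-])cc2)cc1`, differs from compound 3 by nitro in place of hydrogen on an aromatic carbon. Among the measured compounds shown here, no measured pair shows this change alone; compound 1, the only other nitro compound, carries it on a different ring alongside other changes. The step of a 2.1-fold lower number from compound 3 to compound 4 (0.31 log units; beyond the scatter) is expected to be modest, toward a lower number, and may not clear the scatter. Compound 4 is therefore estimated at 60000 nM, within 20000 nM to 180000 nM.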

Compound 4, half-maximal inhibitory concentration: 185000 nM
The estimate for compound 4 lay 3.1-fold (0.49 log units) below the measured number; measured number outside the range, above it.
By their numbers in this assay, from the lowest: compound 1; then compound 2; then compounds 3 and 4 (each within the scatter of the next).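

In this assay the phenyl to 4-nitrophenyl change gives a 1.5-fold higher number from compound 3 to compound 4 (0.18 log units; within the scatter) and so does not separate the two compounds at this position, para to a large group. Among the compounds shown here, this is the first view of nitro on its own, which compound 1 could not give, since its nitro group comes with other changes. Nothing measured here bears on the reason for this result. On these data alone, whether an amine or a carboxylic acid at this same place would also leave the number within the scatter stays open, as does the effect of nitro on the other ring of compound 3.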